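From a 3-Cyanophenyl to a 3,5-Dichlorophenyl Group

The compounds below may be only part of what the source reports. "The series", "measured", "known", "first", "only" and "open" are said of these compounds alone.

Compound 1, `CCc1nc(-c2ccc(OC)cc2)c(C(=O)N2CCN(c3cccc(Cl)c3)CC2)o1`, in a functional assay on HL-60 cells (Homo sapiens) for inhibition, read by MTT assay, with a stated time of 72 h (a lower number here means a stronger inhibitor, a higher number a weaker inhibitor), reaches only a limit, > 1000 nM.
Compound 2, `Cc1nc(-c2ccc(F)cc2)c(C(=O)N2CCN(c3ccc(C(=O)C(C)C)cc3)CC2)o1`, in this assay is reported as "not active" (no number reported).
Compound 3, `Cc1nc(-c2ccccc2)c(C(=O)N2CCN(c3cccc(C#N)c3)CC2)o1`, in this assay gives 39.6 nM.

Within the data shown here, compound 3 thus holds the only true number among the three; compound 1 sits at the limit of > 1000 nM in this assay, at which 1 of the 3 values shown sits, and compound 2 carries no number at all. Compound 4, `Cc1nc(-c2ccccc2)c(C(=O)N2CCN(c3cc(Cl)cc(Cl)c3)CC2)o1`, differs from compound 3 in a single place: 3,5-dichlorophenyl in place of 3-cyanophenyl on an amine nitrogen in a ring. Among the measured compounds shown here, no step between two measured compounds exists here, so the size of this change cannot be read off the data. A modest loss of potency in this assay is expected, with the estimated step of a 3.8-fold higher number from compound 3 to compound 4 (0.58 log units; beyond the scatter) lying just beyond the usual scatter. Compound 4 is therefore estimated at 150 nM, within a range from 30 nM to 1500 nM.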

Compound 4, half-maximal inhibitory concentration: 41.8 nM
For compound 4 the middle estimate is 3.6-fold (0.55 log units) above the measured one; low and high end bracket the measured number.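

In this assay, replacing 3-cyanophenyl with 3,5-dichlorophenyl on the amine nitrogen in the ring gives a 1.1-fold higher number from compound 3 to compound 4 (0.02 log units; within the scatter), so the two groups cannot be told apart at this place. In this pair, then, the nitrile is not needed for a value of this size. Nothing measured here gives a reason for this result.

Still open, going by these compounds, is whether a phenyl group bearing an amine or a carboxylic acid, or a saturated cyclohexyl ring, would serve equally well on this nitrogen. Also open, on these data alone, is whether the same exchange would give a similar result on a core with a longer chain than methyl.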